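Ester Series: Imidazolyl Replacing Trifluoromethylphenoxy

A few compounds are considered here, and "the series" means these few. Any claim that something is new, unique, unknown or untested is made for them only; others in the source may bear on it.

The series shares one core, seen in compound 1 `Cc1ccc(-c2cc(C(=O)Oc3ccc(C(C)C)cc3)n(Cc3ccccc3)n2)cc1` and compound 2 `Cc1ccc(-c2cc(C(=O)Oc3ccc(Oc4ccc(C(F)(F)F)cc4)cc3)n(Cc3ccccc3)n2)cc1`. In a functional assay on the whole organism (strain Swiss albino) for inhibition, with Mus musculus as the target, read by paw edema, with stated times of 30 min and 360 min, at a dose of 100 mg/kg by the subcutaneous route (a lower number here means less inhibition, a higher number more inhibition at the dose given (going by the name of the read-out)), compound 1 gives 31.5%, and compound 2 gives 14.1%, the lowest of the two numbers in hand. Within the data shown here, the only measured step, a number 17.4 percentage points lower from compound 1 to compound 2 (beyond the scatter), lies beyond the scatter and shows that the group at this position of the shared core can move the read-out. Compound 3 `Cc1ccc(-c2cc(C(=O)Oc3ccc(-n4ccnc4)cc3)n(Cc3ccccc3)n2)cc1` is not yet measured; it differs from compound 2 in one place: 1H-imidazol-1-yl in place of 4-(trifluoromethyl)phenoxy on an aromatic carbon. Among the measured compounds shown here, no measured step involves an imidazolyl group, so that step bears on it only loosely, as a gauge of how much this position can shift. Because compound 1 reaches 31.5% with isopropyl in the same place, a step of a number 9.9 percentage points higher from compound 2 to compound 3 (within the scatter) is expected, held with low confidence. Compound 3 is therefore estimated at 24%, with a range from 10% to 38%.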

Compound 3, a percentage reported as inhibition, in the whole organism at one dose (the size of the read-out at that dose, not a potency): 18.8%
Compound 3: middle estimate off by 5.2 percentage points, on the high side, and the stated range covers the measured number.
By their numbers in this assay, from the lowest: compounds 2 and 3 (each within the scatter of the next); then compound 1.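

The exchange of 4-(trifluoromethyl)phenoxy for 1H-imidazol-1-yl gives a number 4.7 percentage points higher from compound 2 to compound 3 (within the scatter), so at this position a phenoxy group and a five-membered aromatic ring with 2 hetero atoms cannot be told apart, despite their different make-up. Isopropyl stays separate from the imidazolyl group as well, with a number 12.7 percentage points lower from compound 1 to compound 3 (beyond the scatter), so among these three compounds, both ring-bearing groups sit apart from isopropyl, and compound 1 alone holds the higher number. Nothing available explains this grouping.

Going by these compounds, it remains open whether the level of compound 1 belongs to isopropyl alone or extends to other open-chain groups, such as a tert-butyl group or a longer alkyl chain. Where an amine or a carboxylic acid at this position would fall is also open.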